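Butoxy to Methyl on Two Related Cores

A few compounds are considered here, and "the series" means these few. Any claim that something is new, unique, unknown or untested is made for them only; others in the source may bear on it.

The measured compounds, with their values in a functional assay on HL-60 cells (Homo sapiens) for cytotoxicity, read by WST assay, with a stated time of 48 h; on this read-out lower numbers stand for an effect already at smaller amounts and higher numbers for an effect only at larger amounts of compound:

Compound 1, `CCCCOc1ccc(C[C@H]2C(=O)OC[C@@H]2Cc2ccccc2)cc1`, gives 23000 nM.
Compound 2, `Cc1ccc(C[C@H]2C(=O)OC[C@@H]2Cc2ccccc2)cc1`, gives 44000 nM.
Compound 3, `CCCCOc1ccccc1C[C@H]1COC[C@@H]1Cc1ccc(Cl)c(Cl)c1`, gives 20000 nM.

Compound 1 and compound 2 share a core and differ by methyl in place of butoxy on an aromatic carbon. The step that this change made was a 1.9-fold higher number from compound 1 to compound 2 (0.28 log units; within the scatter), so within one core the exchange of butoxy for methyl left the read-out essentially where it was. Compound 3 sits on a different core; the difference between the two cores is not broken down here. Compound 4, `Cc1ccccc1C[C@H]1COC[C@@H]1Cc1ccc(Cl)c(Cl)c1`, has not yet been measured in this assay. It differs from compound 3 by methyl in place of butoxy on an aromatic carbon. The place is not identical to that of the earlier exchange: in compound 1 the butoxy stood para to a large group, whereas in compound 3 it stands ortho to a large group, so the two changes are the same kind of change rather than the same change.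

With one precedent only, and that one on another core and at another place around the ring, the expectation rests on the step from compound 1 to compound 2 and little else. The step from compound 3 to compound 4 is estimated at a 1.8-fold higher number from compound 3 to compound 4 (0.24 log units; within the scatter), beside the earlier 1.9-fold higher number from compound 1 to compound 2 (0.28 log units; within the scatter), because compound 3 gives 20000 nM, close to the value of compound 1. For compound 4 the expected value is 35000 nM, with a range from 14000 nM to 90000 nM that is kept wide on account of the changed core and place.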

Compound 4, half-maximal effective concentration: 21000 nM
Beside the measured number, compound 4's estimate is 1.7-fold (0.22 log units) above it, and the stated range covers the measured number.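

On the core of compound 3, methyl in place of butoxy on an aromatic carbon gave a 1.1-fold higher number from compound 3 to compound 4 (0.02 log units; within the scatter) in this assay, so here too the exchange left the read-out where it was. Set beside the earlier exchange on the core of compound 1, the two steps do not differ: the same change on two cores in this assay, a 1.9-fold higher number (0.28 log units; within the scatter) from compound 1 to compound 2 and a 1.1-fold higher number (0.02 log units; within the scatter) from compound 3 to compound 4, 1.8-fold (0.26 log units) apart, within the scatter of two such steps This shows that, across these two pairs, removing butoxy in favour of methyl stayed within the scatter on both cores, but it does not show a general rule for the series: it rests on two pairs only, neither step stands out from the scatter, and the two exchanges sit at different places around the ring, so the effect of the core cannot be separated from that of the place.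

The compounds shown leave open how the read-out would respond to an amine, a carboxylic acid or a chain longer than butoxy on this ring. They also leave open whether methyl in place of butoxy would give the same result on the two cores with the place held the same on both.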